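The source may hold more compounds than are shown below. What is called first, only, known or untested is meant among the compounds shown, and "the series" means these compounds.

Measured so far in an ADME assay on MT4 cells (Homo sapiens) for cytotoxicity, read by MTT assay, with a stated time of 5 days; a higher number here means that more compound is tolerated, a lower number that less compound is tolerated:

Compound 1, `N#C/C=C/c1ccc(C(NC2CC2)c2ccnc(Nc3ccc(C#N)cc3)n2)cc1`: 56100 nM
Compound 2, `CC(O)CNC(c1ccc(C#N)cc1)c1ccnc(Nc2ccc(C#N)cc2)n1`: > 65000 nM, a limit of the assay rather than a number
Compound 3, `CC(C)NC(c1ccnc(Nc2ccc(C#N)cc2)n1)c1ccccc1Cl`: 35500 nM

All three compounds share a core in which a substituted amine sits on a saturated carbon that links two aromatic rings. In this assay compound 1 gives 56100 nM, the higher of the two numbers reported. Compound 3 gives 35500 nM, a value that sits within the usual scatter of the value for compound 1, so no real distinction between the two can be drawn. For compound 2 the assay returns only (the limit of > 65000 nM in this assay, at which 1 of the 3 values shown sits), which marks the edge of what was tested and not a measured number.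

Compound 4, `N#C/C=C/c1ccc(C(NN)c2ccnc(Nc3ccc(C#N)cc3)n2)cc1`, has not yet been tested. It differs from compound 1 in one place: amino in place of cyclopropyl on an amine nitrogen. For the measured compounds named here, no step between measured compounds is available to indicate how such a change affects the read-out, and the numbers known so far are all in the same broad region. On that basis the step of a 1.1-fold lower number from compound 1 to compound 4 (0.05 log units; within the scatter) is expected to stay within the scatter, with neither direction favoured. Compound 4 is therefore estimated at 50000 nM, in a range from 22000 nM to 110000 nM.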

Compound 4, half-maximal cytotoxic concentration: 186000 nM
For compound 4 the middle estimate is 3.7-fold (0.57 log units) below the measured one; measured number above the stated range.
By their numbers in this assay, from the lowest: compounds 3 and 1 (each within the scatter of the next); then compound 4.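

In this assay, for the compounds shown here, putting amino in place of cyclopropyl on the amine nitrogen gives a 3.3-fold higher number from compound 1 to compound 4 (0.52 log units; beyond the scatter), and this is the first step in the set that changes one place only. Going by these compounds alone, it shows that the read-out responds to the group on this nitrogen, with more compound tolerated after the change, whereas the earlier compounds, which offered no such one-place pair, could not show whether this position mattered at all. The change removes a three-membered carbon ring and brings in a single nitrogen with a hydrogen-bond donor and acceptor, but nothing measured here says which of these differences counts, so no cause can be given.

From the compounds shown here alone, a single step cannot separate losing the ring from gaining the nitrogen, and a methyl group or a plain hydrogen on the same amine nitrogen would be needed to pull those two apart, while whether the step carries over to other compounds with the shared core also stays open. Compound 2 differs from compound 1 in more than one place and gives only a limit of the assay, not a number: the limit of > 65000 nM in this assay, at which 1 of the 4 values shown sits.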